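This account rests on a few compounds, and the source may have more. Where it says the series, first, only, none or still open, it means among the compounds named here.

In an ADME assay on MT4 cells (Homo sapiens) for cytotoxicity, read by MTT assay (on this read-out higher numbers stand for lower toxicity in this test and lower numbers for higher toxicity in this test), compound 1 (`O=C(CSc1nncnc1-c1cccc2ccccc12)Nc1ccc(Cl)cc1Cl`) gives 254000 nM and sits within the usual scatter of its two measured relatives: compound 2 (`Cc1ccccc1NC(=O)CSc1nncnc1-c1ccccc1Cl`) gives 142000 nM and compound 3 (`CCOC(=O)c1ccc(NC(=O)CSc2nncnc2-c2cccc3ccccc23)c(Cl)c1`) gives 150000 nM on the same read-out. Compound 4 (`O=C(CSc1nncnc1-c1cccc2ccccc12)Nc1ccccc1`) has not yet been measured. It carries phenyl in place of 2,4-dichlorophenyl on an amide-type nitrogen. For the measured compounds named here, the one measured step that touches this aromatic group is a 1.7-fold lower number from compound 1 to compound 3 (0.23 log units; within the scatter) with ethoxycarbonyl in place of chloro on an aromatic carbon. That step lies within the scatter, but it is a single example and a different exchange, so it offers only modest guidance. Compound 2 differs from compound 1 in more than one place and provides no clean comparison. A step of a 1.3-fold lower number from compound 1 to compound 4 (0.10 log units; within the scatter) is therefore expected, which means no change beyond the scatter in this assay and no firm direction. The estimate for compound 4 is 200000 nM (expected range 90000 nM to 400000 nM).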

Compound 4, half-maximal cytotoxic concentration: 154000 nM
Estimate against measurement, compound 4: 1.3-fold (0.11 log units) above; the range from low to high includes it.
By their numbers in this assay, from the lowest: compounds 2, 3, 4 and 1 (each within the scatter of the next).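

Exchanging 2,4-dichlorophenyl for phenyl on the amide-type nitrogen gives a 1.6-fold lower number from compound 1 to compound 4 (0.22 log units; within the scatter) in this assay. The earlier step, a 1.7-fold lower number from compound 1 to compound 3 (0.23 log units; within the scatter), exchanged one chloro for ethoxycarbonyl and kept an aromatic ring that still carried substituents, whereas this one takes both chlorine atoms away and leaves the ring bare. Even this plain phenyl ring cannot be told apart from the 2,4-dichlorophenyl ring in this test, and no measurement shown explains this result.

As far as these compounds go, whether a carboxylic acid or an amine on the phenyl ring would give a step beyond the scatter remains open. So does the outcome of replacing the aromatic ring with a saturated cyclohexyl ring on the same nitrogen.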